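Aryl amine swap on a quinazoline-type series, cytotoxicity

This account rests on a few compounds, and the source may have more. Where it says the series, first, only, none or still open, it means among the compounds named here.

Compound 3 `Cc1ccccc1Nc1nc(SCc2ccc(C(F)(F)F)cc2)nc2ccccc12` gives 24400 nM in a functional assay on MGC-803 cells (Homo sapiens) for cytotoxicity, read by MTT assay, with a stated time of 72 h; a higher number here means a weaker inhibitor, a lower number a stronger inhibitor. Among the two numbers in hand it is the higher one; its nearest neighbour is compound 1 `CCCCCCNc1nc(SCc2ccc(C(F)(F)F)cc2)nc2ccccc12`, which in this assay gives 13100 nM, and the step of a 1.9-fold higher number from compound 1 to compound 3 (0.27 log units; within the scatter) lies within the scatter. Compound 2 `CCCCCCCCCCCCNc1nc(SCc2ccc(C(F)(F)F)cc2)nc2ccccc12` reaches only a limit in this assay, > 50000 nM. The step of an at least 3.8-fold higher number from compound 1 to compound 2 (0.58 log units; beyond the scatter) is the only one beyond the scatter, and it follows a chain extension rather than an aryl exchange. Compound 4 `FC(F)(F)c1ccc(CSc2nc(Nc3ccc(C(F)(F)F)cc3)c3ccccc3n2)cc1` differs from compound 3 by 4-(trifluoromethyl)phenyl in place of 2-methylphenyl on a nitrogen on an aromatic ring. Within the data shown here, no measured step exchanges one aryl group for another on that nitrogen, so the measured steps give no direct guide; the only aryl-bearing step, the one from compound 1 to compound 3, is within the scatter. The step of a 1.1-fold higher number from compound 3 to compound 4 (0.06 log units; within the scatter) is therefore expected to stay within the scatter. Compound 4 is estimated at 28000 nM, with a range from 9000 nM to 90000 nM.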

Compound 4, half-maximal inhibitory concentration: 6170 nM
For compound 4 the middle estimate is 4.5-fold (0.66 log units) above the measured one, and the stated range ends above it.
By their numbers in this assay, from the lowest: compound 4; then compounds 1 and 3 (each within the scatter of the next). At a limit, above all of these: compound 2.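

In this assay, exchanging one aryl group for another on a nitrogen on an aromatic ring gives a 4.0-fold lower number from compound 3 to compound 4 (0.60 log units; beyond the scatter), which shows that the choice of aryl group at this position can move the reading beyond the scatter. An aryl group can also separate from hexyl here, with a 2.1-fold lower number from compound 1 to compound 4 (0.33 log units; beyond the scatter), whereas 2-methylphenyl did not, with a 1.9-fold higher number from compound 1 to compound 3 (0.27 log units; within the scatter), so the outcome depends on the aryl group and not simply on having one. Nothing given here accounts for the change.

Going by these compounds, what a plain phenyl, a 4-methylphenyl or a 2-(trifluoromethyl)phenyl group on this nitrogen would give stays open, so the step cannot be assigned to the trifluoromethyl group or to the loss of the methyl group. Also open, on these data alone, is how a pyridine ring or a 4-methoxyphenyl group would read in this assay.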